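This account rests on a few compounds, and the source may have more. Where it says the series, first, only, none or still open, it means among the compounds named here.

Of the compounds shown here, two have been measured so far in a functional assay on A2780 ADR cells (Homo sapiens) for cytotoxicity, read by MTT assay, with a stated time of 24 h; on this read-out lower numbers stand for stronger inhibition and higher numbers for weaker inhibition: compound 1 (`CCCCC[C@@H](C[C@@H](O)C[C@H]1CC=CC(=O)O1)OC`) gives 25200 nM and compound 2 (`CCCCC[C@H](CCC[C@H]1CC=CC(=O)O1)OC`) gives 12200 nM. Compound 2 therefore holds the lower number of the two, which means the stronger inhibition, and the gap between them lies just beyond the usual scatter of repeated measurements. Neither number is strong in absolute terms, since both sit in the micromolar range.

Compound 3 (`CCCCC[C@@H](CCC[C@H]1CC=CC(=O)O1)OC`) has not yet been measured. It has the same atoms and bonds as compound 2 and differs only in configuration as drawn (the two compounds have the same atoms and bonds and differ only in configuration as drawn: 1 of 2 stereo elements differ; a stereocentre at a saturated chain carbon is drawn R in compound 2 and S in compound 3): a stereocentre at a saturated chain carbon is drawn R in compound 2 and S in compound 3. Within the data shown here, no pair of measured compounds here shows what a change of configuration alone does in this assay, so any forecast is uncertain and stays close to the value of compound 2. The expected step of a 1.1-fold higher number from compound 2 to compound 3 (0.06 log units; within the scatter) is no larger than the scatter, with no firm direction. For compound 3 the estimated value is 14000 nM, with an expected range of 6000 nM to 32000 nM.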

Compound 3, half-maximal inhibitory concentration: 9000 nM
The estimate for compound 3 lay 1.6-fold (0.19 log units) above the measured number; low and high end bracket the measured number.
By their numbers in this assay, from the lowest: compounds 3 and 2 (each within the scatter of the next); then compound 1.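

In this assay, drawing the stereocentre at the saturated chain carbon as S rather than R gives a 1.4-fold lower number from compound 2 to compound 3 (0.13 log units; within the scatter), so at this carbon the change of configuration has no effect that can be told apart from the usual scatter of repeated measurements. The comparison is a clean one, with nothing else varying: the fact that compounds 2 and 3 differ only in the configuration as drawn. Hydrogen in place of hydroxy on a saturated chain carbon bound to two saturated chain carbons gives a 2.8-fold lower number from compound 1 to compound 3 (0.45 log units; beyond the scatter), a modest step but one that stands beyond the scatter, so among the changes shown so far this one, and not the change of configuration, is the one that clearly moves the number.

Going by these compounds, whether an amine or a carboxylic acid on that same saturated chain carbon would shift the number further than hydrogen does remains open, as does the effect of a longer chain in place of the existing one. The compounds shown also offer no pair that tests a change of configuration with the hydroxy in place.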